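Changing the Sulfur Side Chain of Compound 2

A few compounds are considered here, and "the series" means these few. Any claim that something is new, unique, unknown or untested is made for them only; others in the source may bear on it.

Measured in a functional assay on HT cells (Homo sapiens) for antiproliferative activity, read by fluorescence, with a stated time of 72 h; a higher number here means a weaker inhibitor of growth, a lower number a stronger inhibitor of growth:
- compound 1 `CC(C)c1n[nH]c2c(NCc3ccc(-c4ccccn4)cc3)nc(SC(C)C(C)O)nc12` gives 190 nM
- compound 2 `C=CCSc1nc(NCc2ccc(-c3ccccn3)cc2)c2[nH]nc(C(C)C)c2n1` gives 1010 nM

Compound 2 holds the higher number of the pair. Compound 3 `COCSc1nc(NCc2ccc(-c3ccccn3)cc2)c2[nH]nc(C(C)C)c2n1` differs from it as follows: methoxy in place of vinyl on a saturated chain carbon bound to a sulfur. In words, this is methoxy in place of vinyl on a saturated chain carbon bound to a sulfur. Among the compounds with values here, only one measured step bears on this change: a 5.3-fold higher number from compound 1 to compound 2 (0.73 log units; beyond the scatter), where allyl replaced 2-hydroxy-1-methylpropyl on a sulfur. Given that modest step, a small move toward a lower number is expected, possibly within the scatter. The estimated change is a 1.4-fold lower number from compound 2 to compound 3 (0.16 log units; within the scatter). Compound 3 is expected at 700 nM, within an estimated range of 300 nM to 1600 nM.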

Compound 3, concentration for 50% growth inhibition: 340 nM
Beside the measured number, compound 3's estimate is 2.1-fold (0.31 log units) above it; the measured number falls inside the stated range.
By their numbers in this assay, from the lowest: compounds 1 and 3 (each within the scatter of the next); then compound 2.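

Replacing vinyl with methoxy on a saturated chain carbon bound to a sulfur gives a 3.0-fold lower number from compound 2 to compound 3 (0.47 log units; beyond the scatter) in this assay, so this position responds to a change as small as this one. The step of a 1.8-fold higher number from compound 1 to compound 3 (0.25 log units; within the scatter) is within the scatter, so the methoxymethyl and 2-hydroxy-1-methylpropyl chains cannot be told apart here, although the allyl chain of compound 2 stands apart from both. Nothing available explains the difference between the allyl and methoxymethyl chains.

Going by these compounds, it remains open how an amine or a carboxylic acid on the sulfur side chain would fare. A longer chain carrying a methoxy group is equally untested among the compounds shown.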